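The source may report more compounds than this note shows. Statements on the series, on what has been measured and on what is new or still open speak of the compounds shown alone.

Measured in a functional assay on MC-38 cells (Mus musculus) for antiproliferative activity; a lower number here means a stronger inhibitor, a higher number a weaker inhibitor:
compound 1 `N#Cc1c[nH]c2c(NS(=O)(=O)c3ccc(C(N)=O)cc3)cccc12`: 0.68 ug/mL
compound 2 `NC(=O)c1ccc(S(=O)(=O)Nc2cccc3c(Cl)c[nH]c23)cc1`: 0.19 ug/mL
compound 3 `CS(=O)(=O)Nc1ccccc1S(=O)(=O)Nc1cccc2c(Cl)c[nH]c12`: 45 ug/mL

Compound 2 has the lowest number of the three in this assay. Compound 4 `NS(=O)(=O)Cc1ccc(S(=O)(=O)Nc2cccc3c(Cl)c[nH]c23)cc1` differs from it by sulfamoylmethyl in place of carbamoyl on an aromatic carbon, with sulfamoylmethyl in place of carbamoyl on an aromatic carbon, para to a large group. For the measured compounds named here, the only measured single change, a 3.6-fold lower number from compound 1 to compound 2 (0.55 log units; beyond the scatter), is modest and swaps chloro for cyano elsewhere, so it does not test this group. Compound 3 also carries chloro but gives 45 ug/mL, which shows that the number can move far when the other end of the molecule differs. A modest rise is therefore expected, with the estimated step being a 2.1-fold higher number from compound 2 to compound 4 (0.32 log units; beyond the scatter). For compound 4 the expected value is 0.4 ug/mL, within an estimated range of 0.08 ug/mL to 3 ug/mL.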

Compound 4, half-maximal inhibitory concentration: 0.12 ug/mL
Estimate against measurement, compound 4: 3.3-fold (0.52 log units) above; measured number inside the range.
By their numbers in this assay, from the lowest: compounds 4 and 2 (each within the scatter of the next); then compound 1; then compound 3.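

The step of a 1.6-fold lower number from compound 2 to compound 4 (0.20 log units; within the scatter) in this assay comes with sulfamoylmethyl in place of carbamoyl on an aromatic carbon para to a large group. This first single change at this position shows that carbamoyl is not needed to hold the level of compound 2, and that the position accepts a group of 5 heavy atoms with no shift beyond the scatter. No measured property accompanies this result, so nothing can be said about its cause.

Going by these compounds, an amine, a carboxylic acid or a longer chain at this position remains open. Also open, on these data alone, is whether sulfamoylmethyl holds this level with cyano in place of chloro.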